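This account rests on a few compounds, and the source may have more. Where it says the series, first, only, none or still open, it means among the compounds named here.

Going by the values given here, in a functional assay on HCT-15 cells (Homo sapiens) for cytotoxicity, in the presence of a further agent that is not named here (on this read-out lower numbers stand for stronger inhibition and higher numbers for weaker inhibition), compound 1 `Cc1cccc(-c2cc(-c3ccc(Cl)o3)cc(-c3ccsc3)n2)c1` gives 21700 nM and holds the higher of the two exact numbers so far. Compound 2 `Clc1ccc(-c2cc(-c3cccnc3)nc(-c3cccs3)c2)o1` gives 1240 nM and sits lower by more than the usual scatter. Compound 3 `Clc1ccc(-c2cc(-c3ccoc3)cc(-c3ccsc3)n2)cc1` reads > 100000 nM and this is a limit of the assay, not a number. Compound 4 `Cc1ccc(-c2cc(-c3ccc(Cl)o3)cc(-c3ccsc3)n2)cc1` has the same atoms as compound 1 joined differently: 4-methylphenyl in place of 3-methylphenyl on an aromatic carbon and the rest stays the same. Among the compounds with values here, no measured pair here differs in one place, so the expectation rests on compound 1 at 21700 nM alone. The estimated step of a 1.1-fold lower number from compound 1 to compound 4 (0.04 log units; within the scatter) is expected to stay within the usual scatter, with no clear direction. For compound 4 the expected value is 20000 nM with an estimated range from 6000 nM to 60000 nM as the likely span.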

Compound 4, half-maximal inhibitory concentration: 7410 nM
Beside the measured number, compound 4's estimate is 2.7-fold (0.43 log units) above it; measured number inside the range.
By their numbers in this assay, from the lowest: compound 2; then compound 4; then compound 1. At a limit, above all of these: compound 3.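

Moving only the methyl group around the phenyl ring, on the aromatic carbon next to the ring nitrogen, gives in this assay a 2.9-fold lower number from compound 1 to compound 4 (0.47 log units; beyond the scatter). Going by these compounds alone, this is the first pair here that differs in one place, and it shows a modest change in the result between two compounds that keep the same atoms and differ only in the methyl group's place. Nothing measured here accounts for this step.

The compounds shown leave open how 2-methylphenyl, or a phenyl ring carrying an amine, would read at this place. They also leave open whether the same shift would hold with different groups elsewhere on the core.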